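A Fluorine Added to the Benzyl Ring

The source may report more compounds than this note shows. Statements on the series, on what has been measured and on what is new or still open speak of the compounds shown alone.

Compound 3 `Cc1ccc(NC(=O)NC(=O)c2ccc(OCc3ccccc3)cc2)cc1-c1nc2ccccc2[nH]1` carries an unsubstituted benzyloxy group on the shared core. In a functional assay on MGC-803 cells (Homo sapiens) for inhibition, read by MTT assay, with a stated time of 48 h (a higher number here means a weaker inhibitor, a lower number a stronger inhibitor), compound 3 gives 39400 nM, the higher of the two numbers available, so it is the weaker of the two measured inhibitors. The nearest number belongs to compound 1 `Cc1ccc(NC(=S)NC(=O)c2ccc(OCc3cccc(C(F)(F)F)c3)cc2)cc1-c1nc2ccccc2[nH]1`, which gives 5210 nM in this assay. Compound 2 `Cc1ccc(NC(=S)NC(=O)c2ccc(OCc3cccc(Cl)c3Cl)cc2)cc1-c1nc2ccccc2[nH]1` returns only a limit of this assay, > 100000 nM. Compounds 1 and 3 differ in two places at once, so their values can only be set side by side, not read as a single step.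

Compound 4 `Cc1ccc(NC(=O)NC(=O)c2ccc(OCc3cccc(F)c3)cc2)cc1-c1nc2ccccc2[nH]1` differs from compound 3 in one place: fluoro in place of hydrogen on an aromatic carbon. Going by the values given here, the only measured step that touches the same benzyl ring is an at least 19-fold higher number from compound 1 to compound 2 (1.28 log units; beyond the scatter), a swap of the whole substitution pattern on that ring; it ends at the limit of > 100000 nM in this assay, at which 1 of the 3 values shown sits, and shows that what sits on this ring can move the number a great deal. A single fluoro is a far smaller alteration than that swap, so the step of a 1.3-fold lower number from compound 3 to compound 4 (0.12 log units; within the scatter) is expected to stay within the usual scatter, in either direction. Compound 4 is therefore estimated at 30000 nM, with a likely range from 10000 nM to 100000 nM.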

Compound 4, half-maximal inhibitory concentration: 44800 nM
The estimate for compound 4 lay 1.5-fold (0.17 log units) below the measured number, within the range that was stated.
By their numbers in this assay, from the lowest: compound 1; then compounds 3 and 4 (each within the scatter of the next). At a limit, above all of these: compound 2.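

In this assay, the step of a 1.1-fold higher number from compound 3 to compound 4 (0.06 log units; within the scatter) lies within the scatter, so no effect of the added fluoro can be read at this place. Going by these compounds alone, the earlier compounds showed only that exchanging a whole substitution pattern on the benzyl ring can go with a large step; compound 4 adds the first single-atom change on that ring, on an aromatic carbon meta to a large group, and this change leaves compound 3 and compound 4 indistinguishable in this assay. Within the data shown here, compound 2 remains the only compound here with a limit rather than a number: the limit of > 100000 nM in this assay, at which 1 of the 4 values shown sits.

The compounds shown leave open whether a single group of another kind at this same place on the core of compound 3, such as a methoxy group, an amine or a carboxylic acid, would give a step beyond the scatter. Among these compounds, they also leave open how much of the gap between compound 1 and compound 3 belongs to the group on the benzyl ring, as those two compounds differ in two places at once and no single step joins them.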